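Thiourea sulfonamides: a methyl on the pyrimidine ring

The compounds below may be only part of what the source reports. "The series", "measured", "known", "first", "only" and "open" are said of these compounds alone.

Compound 1 `Cc1noc(NS(=O)(=O)c2ccc(N/C(S)=N\c3ccnc4cc(C(F)(F)F)ccc34)cc2)c1C` in a functional assay on HT-1080 cells (Homo sapiens) for antiproliferative activity, read by sulforhodamine B assay, with a stated time of 48 h; a lower number here means a stronger inhibitor, a higher number a weaker inhibitor: 27700 nM
Compound 2 `O=S(=O)(Nc1ncccn1)c1ccc(N/C(S)=N\c2ccnc3cc(C(F)(F)F)ccc23)cc1` in this assay: 29100 nM

Among the compounds with values here, the one step known, a 1.1-fold higher number from compound 1 to compound 2 (0.02 log units; within the scatter), lies within the scatter, so compound 2 and compound 1 sit side by side with neither set apart. Compound 3 `Cc1ccnc(NS(=O)(=O)c2ccc(N/C(S)=N\c3ccnc4cc(C(F)(F)F)ccc34)cc2)n1` differs from compound 2 by methyl in place of hydrogen on an aromatic carbon. Within the data shown here, no measured step touches this position; the only step on record, the heterocycle swap on the sulfonamide nitrogen, hardly moved the number. No step beyond the scatter is therefore expected in this assay, meaning a 1.0-fold lower number from compound 2 to compound 3 (0.02 log units; within the scatter). Compound 3 is estimated at 28000 nM, with a range of 12000 nM to 65000 nM.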

Compound 3, half-maximal inhibitory concentration: 28700 nM
For compound 3 the middle estimate is 1.0-fold (0.01 log units) below the measured one; the range from low to high includes it.
By their numbers in this assay, from the lowest: compounds 1, 3 and 2 (each within the scatter of the next).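

On the pyrimidine ring itself, 4-methylpyrimidin-2-yl in place of pyrimidin-2-yl gives a 1.0-fold lower number from compound 2 to compound 3 (0.01 log units; within the scatter) in this assay, so a methyl at this position leaves the number within the scatter. The methylated ring also compares with the 3,4-dimethyl-1,2-oxazol-5-yl group of compound 1, with a 1.0-fold higher number from compound 1 to compound 3 (0.02 log units; within the scatter), so this heterocycle swap also stays within the scatter. No measurement at hand offers an explanation for these results.

Going by these compounds, whether an amine or a carboxylic acid at this position would shift the number remains open. So does the effect of any change elsewhere on the shared core.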